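Swapping Ethynyl for Fluoro: Expected Effect on Cell Tolerance

The source may report more compounds than this note shows. Statements on the series, on what has been measured and on what is new or still open speak of the compounds shown alone.

Compound 1 `C#Cc1c([C@@H]2O[C@H](CO)[C@@H](O)[C@H]2O)ccnc1C(N)=O` carries an ethynyl group on its shared core. In an ADME assay on MDCK cells (Canis lupus familiaris) for cytotoxicity, read by CellTiter-Glo, with a stated time of 10 min (a higher number here means that more compound is tolerated, a lower number that less compound is tolerated), compound 1 gives 98000 nM. Compound 2 `NC(=O)c1nccc([C@@H]2O[C@H](CO)[C@@H](O)[C@H]2O)n1` gives > 200000 nM in this assay, which is a limit of the assay and not a number. Compound 1 thus stands as the only plain number shown, the other result being (the limit of > 200000 nM in this assay, at which 1 of the 2 values shown sits). Compound 3 `NC(=O)c1nccc([C@@H]2O[C@H](CO)[C@@H](O)[C@H]2O)c1F` differs from compound 1 by fluoro in place of ethynyl on an aromatic carbon. Going by the values given here, no measured step matches this change, so in this assay nothing beyond the usual scatter is expected, with perhaps a slight rise. Compound 3 is estimated at 140000 nM, between 60000 nM and 300000 nM, an expected step of a 1.4-fold higher number from compound 1 to compound 3 (0.15 log units; within the scatter).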

Compound 3, half-maximal cytotoxic concentration: > 400000 nM
Compound 3: no number, only a limit; the forecaster's own chance of this, stated with the estimate: 40%; at least 2.8-fold (0.45 log units) between middle value and limit.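

In this assay, going by these compounds alone, the one measured change at this position, an aromatic carbon ortho to a carbamoyl group, is fluoro in place of ethynyl, and it gives an at least 4.0-fold higher number from compound 1 to compound 3 (0.61 log units; beyond the scatter). So swapping this small group alone can shift cell tolerance by more than the usual scatter, though this rests on a single pair. The result for compound 3 is a limit and not a number, so the true size of the step stays unknown: the limit of > 400000 nM in this assay, at which 1 of the 3 values shown sits.

Going by these compounds, whether the shift comes from losing ethynyl or from gaining fluoro remains open. An amine, a methyl group or a longer chain on this carbon could help separate the two.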